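The source may report more compounds than this note shows. Statements on the series, on what has been measured and on what is new or still open speak of the compounds shown alone.

Measured in a functional assay on Ehrlich cells (Mus musculus) for antiproliferative activity, read by trypan blue exclusion, with a stated time of 2 h, tested at 100 ug/mL; a higher number here means a stronger effect of the compound at the concentration tested, a lower number a weaker effect:
Compound 1, `COc1ccccc1C1C(C#N)=C(N)N(c2ccc(S(N)(=O)=O)cc2)C2=C1C(=O)CCC2`, gives 0%.
Compound 2, `COc1cc(CC2C(C#N)=C(N)N(c3ccc(S(N)(=O)=O)cc3)C3=C2C(=O)CCC3)ccc1O`, gives 100%.

Compound 2 stands highest of the two numbers; its nearest neighbour is compound 1, and the step of a number 100 percentage points higher from compound 1 to compound 2 (beyond the scatter) sets them apart, beyond the scatter. Compound 3, `N#CC1=C(N)N(c2ccc(S(N)(=O)=O)cc2)C2=C(C(=O)CCC2)C1c1ccc([N+](=O)[O-])cc1`, has not yet been measured. It differs from compound 2 in one place: 4-nitrophenyl in place of 4-hydroxy-3-methoxybenzyl on a saturated ring carbon. Among the compounds with values here, only one measured step exists, a number 100 percentage points higher from compound 1 to compound 2 (beyond the scatter), and it exchanges a different group on the same saturated ring carbon: 2-methoxyphenyl gave no effect, 4-hydroxy-3-methoxybenzyl gave the full effect. Within the data shown here, no measured pair shows what 4-nitrophenyl does on that carbon. Like compound 1, compound 3 carries a phenyl group rather than a benzyl group there. Because compound 1 gives 0% with a phenyl group on that carbon, compound 3 is expected to come out lower than compound 2, though a single comparison leaves this very uncertain. The step of a number 60 percentage points lower from compound 2 to compound 3 (beyond the scatter) is therefore expected. The estimate for compound 3 is 40%, with a range from 0% to 90%.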

Compound 3, a percentage reported as activity, at one concentration (the size of the read-out at that concentration, not a potency): 100%
The estimate for compound 3 lay 60 percentage points below the measured number, and the stated range ends below it.
By their numbers in this assay, from the lowest: compound 1; then compounds 2 and 3 (each within the scatter of the next).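

In this assay, putting 4-nitrophenyl in place of 4-hydroxy-3-methoxybenzyl on the saturated ring carbon gives no change at the digits printed from compound 2 to compound 3 (within the scatter), so a benzyl group on this carbon is not required for the full effect seen at this concentration. Replacing 2-methoxyphenyl with 4-nitrophenyl on the same carbon gives a number 100 percentage points higher from compound 1 to compound 3 (beyond the scatter), which shows that a phenyl group directly on this carbon does not by itself remove the effect: what it carries matters, and the effect here ranges from none to full among the compounds shown. Nothing available explains why these groups behave so differently.

With a single concentration, the read-out cannot show whether compound 2 and compound 3 would still match at lower doses, where one of them could show a stronger effect than the other. Also open is what this carbon tolerates beyond the three groups shown, such as a plain phenyl group or a phenyl group carrying an amine or a carboxylic acid, which would help show whether the 4-nitrophenyl result reflects the nitro group itself or simply the absence of the 2-methoxy group.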